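A Nitro Group Replaces Chlorine on an Inactive Series

The compounds below may be only part of what the source reports. "The series", "measured", "known", "first", "only" and "open" are said of these compounds alone.

Three compounds share one core and differ only in the group on the outer ring nitrogen. Compound 1 `COc1ccc(-c2nnc(N3CCN(C(=O)CN4CCN(c5ccccc5)CC4)CC3)nc2-c2ccc(OC)cc2)cc1` carries a plain phenyl there, compound 2 `COc1ccc(-c2nnc(N3CCN(C(=O)CN4CCN(c5cccc(OC)c5)CC4)CC3)nc2-c2ccc(OC)cc2)cc1` a methoxyphenyl, and compound 3 `COc1ccc(-c2nnc(N3CCN(C(=O)CN4CCN(c5cccc(Cl)c5)CC4)CC3)nc2-c2ccc(OC)cc2)cc1` a 3-chlorophenyl. All three were tested in a functional assay on MCF7 cells (Homo sapiens) for cytotoxicity, read by MTT assay, with a stated time of 24 h; on this read-out lower numbers stand for stronger inhibition and higher numbers for weaker inhibition. In this assay compound 1 gives > 863000 nM, which is a limit of the measurement and not a number. Compound 2 likewise stops at a limit, > 821000 nM. Compound 3 too gives only a limit, > 814000 nM. With every value a limit, the steps a step that the two limits leave unreadable from compound 1 to compound 2, a step that the two limits leave unreadable from compound 1 to compound 3 and a step that the two limits leave unreadable from compound 2 to compound 3 cannot be read in size or direction; what they show is that none of the three exchanges on that ring brought the series into the measurable range. Compound 3 thus stands where its two companions stand, at a limit.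

Compound 4 `COc1ccc(-c2nnc(N3CCN(C(=O)CN4CCN(c5ccc([N+](=O)[O-])cc5)CC4)CC3)nc2-c2ccc(OC)cc2)cc1` is the next exchange: 4-nitrophenyl in place of 3-chlorophenyl on an amine nitrogen in a ring. The three measured steps bear on it only in that each change at this position left the read-out at a limit. Among the measured compounds shown here, no step of readable size exists to set a direction, so the estimated step that the limit leaves unreadable from compound 3 to compound 4 is none beyond the scatter. Compound 4 is therefore expected to give about 850000 nM in this assay, within an estimated range from 200000 nM to 2000000 nM, most likely again reported only as a limit.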

Compound 4, half-maximal inhibitory concentration: > 801000 nM
Compound 4 gave a limit, no number; the forecaster's own chance of this, stated with the estimate: 85%; the middle value does not contradict the limit.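

In this assay compound 4 gives > 801000 nM, which is a limit and not a number. Its steps from compound 1, compound 2 and compound 3 therefore cannot be read in size or direction. The compounds shown leave open whether any group at this position brings the shared core into the measurable range.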